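This account rests on a few compounds, and the source may have more. Where it says the series, first, only, none or still open, it means among the compounds named here.

Measured so far:
Compound 1, `CC1(C)[C@H]2CC[C@]1(C)N(Cc1cn(-c3ccc(C#N)cc3)nn1)C(=O)C2`: 250 nM in a functional assay on PANC-1 cells (Homo sapiens) for inhibition, read by MTT assay, with a stated time of 24 h; a lower number here means a stronger inhibitor, a higher number a weaker inhibitor
Compound 2, `CC1(C)[C@H]2CC[C@]1(C)N(Cc1cn(-c3ccc(F)cc3)nn1)C(=O)C2`: 110 nM in this assay
Compound 3, `CC1(C)[C@H]2CC[C@]1(C)N(Cc1cn(-c3ccc(O)cc3)nn1)C(=O)C2`: 100 nM in this assay

Compound 1 gives the highest number of the three, so it is the weakest inhibitor here. Replacing its cyano gave a 2.3-fold lower number from compound 1 to compound 2 (0.36 log units; beyond the scatter) and a 2.5-fold lower number from compound 1 to compound 3 (0.40 log units; beyond the scatter), both modest gains beyond the scatter, while compound 2 and compound 3 sit within the scatter of each other, a 1.1-fold lower number from compound 2 to compound 3 (0.04 log units; within the scatter).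

Compound 4, `COc1cccc(-n2cc(CN3C(=O)C[C@@H]4CC[C@@]3(C)C4(C)C)nn2)c1`, differs from compound 1 in one place: 3-methoxyphenyl in place of 4-cyanophenyl on an aromatic nitrogen. Going by the values given here, no measured pair exchanges a 4-cyanophenyl for a 3-methoxyphenyl, so the two earlier steps are only loose guides. Among the compounds with values here, both show that moving away from the cyano lowered the number modestly, and nothing among the measured compounds points the other way. A modest drop from compound 1 in this assay is therefore expected, roughly a 1.7-fold lower number from compound 1 to compound 4 (0.22 log units; within the scatter), though a result within the scatter would not surprise. The estimate for compound 4 is 150 nM, with a range from 60 nM to 400 nM.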

Compound 4, half-maximal inhibitory concentration: 860 nM
The estimate for compound 4 lay 5.7-fold (0.76 log units) below the measured number; the measured number lies above the stated range.
By their numbers in this assay, from the lowest: compounds 3 and 2 (each within the scatter of the next); then compound 1; then compound 4.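

Every earlier replacement of the 4-cyanophenyl on this aromatic nitrogen lowered the number, but 3-methoxyphenyl raises it (a 3.4-fold higher number from compound 1 to compound 4 (0.54 log units; beyond the scatter)), so leaving the 4-cyanophenyl does not by itself give a stronger inhibitor in this assay. The gaps to the two strongest compounds are wider still (an 8.6-fold higher number from compound 3 to compound 4 (0.93 log units; beyond the scatter); a 7.8-fold higher number from compound 2 to compound 4 (0.89 log units; beyond the scatter)), which makes compound 4 the weakest of the four and shows that this position tolerates a much wider spread than the first three compounds suggested. Nothing available explains this reversal.

Compound 4 changes both the group on the phenyl ring and its place, and no compound shown separates the two. As far as these compounds go, how an amine or a carboxylic acid would fare on that ring also remains open.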